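Methyl Position on the Anilino Ring of Compound 3

The source may hold more compounds than are shown below. What is called first, only, known or untested is meant among the compounds shown, and "the series" means these compounds.

Measured compounds:
compound 1 `COc1cc(/C=C/C(=O)c2sc(Nc3cccc(Cl)c3)nc2C)cc(OC)c1OC` — 14000 nM
compound 2 `COc1cc(/C=C/C(=O)c2sc(Nc3ccccc3)nc2C)cc(OC)c1OC` — > 25000 nM
compound 3 `COc1cc(/C=C/C(=O)c2sc(Nc3ccc(C)cc3)nc2C)cc(OC)c1OC` — > 25000 nM

For the measured compounds named here, in a functional assay on Bel-7402 cells (Homo sapiens) for cytotoxicity, read by MTT assay (a higher number here means a weaker inhibitor, a lower number a stronger inhibitor), compound 1 gives 14000 nM and is the only compound with a number rather than a limit. For compound 2 the value > 25000 nM is a limit of the assay. For compound 3 the value > 25000 nM is likewise a limit, so compound 3 stands at the edge of what this assay can report, as stated in the limit of > 25000 nM in this assay, at which 2 of the 3 values shown sit.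

Compound 4 `COc1cc(/C=C/C(=O)c2sc(Nc3cccc(C)c3)nc2C)cc(OC)c1OC` differs from compound 3 by 3-methylphenyl in place of 4-methylphenyl on a nitrogen on an aromatic ring. Going by the values given here, two measured steps touch this change. The step of an at least 1.7-fold higher number from compound 1 to compound 3 (0.25 log units; that floor lies within the scatter) swaps a 3-chlorophenyl for a 4-methylphenyl and reads as a loss that cannot be sized. The step that the two limits leave unreadable from compound 2 to compound 3 adds the methyl and is unreadable, because both ends are limits. Compound 4 keeps the methyl but places it where compound 1 carried its chloro, so a value near the limit, perhaps slightly under it, is expected.

Compound 4 is therefore expected to give 20000 nM in this assay, within 8000 nM to 40000 nM, which is an expected step of an at least 1.2-fold lower number from compound 3 to compound 4 (0.09 log units; that floor lies within the scatter).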

Compound 4, half-maximal inhibitory concentration: > 25000 nM
Compound 4: a limit, no number (the forecaster's own chance of this, stated with the estimate: 45%); at least 1.2-fold (0.09 log units) between middle value and limit.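

In this assay compound 4 gives > 25000 nM, which is a limit of the assay and not a number. For the compounds shown here, compound 4 adds a direct comparison with compound 1, the only compound with a number: with the 3-methylphenyl in place of the 3-chlorophenyl, methyl stands in place of chloro on the same aromatic carbon, and the step reads an at least 1.7-fold higher number from compound 1 to compound 4 (0.25 log units; that floor lies within the scatter). This is a floor and not a size, so it does not establish a difference between methyl and chloro, and the steps among compound 2, compound 3 and compound 4 cannot be read at all, so moving the methyl has no measurable outcome here: the limit of > 25000 nM in this assay, at which 3 of the 4 values shown sit.

On these data alone, how far compound 2, compound 3 and compound 4 lie from one another stays open, since none of the three has a number in this assay. Also open, as far as these compounds go, is whether the number seen for compound 1 belongs to chloro or to its place on the ring, a question that a 4-chlorophenyl or a 3-bromophenyl on the same nitrogen would address.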